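This account rests on a few compounds, and the source may have more. Where it says the series, first, only, none or still open, it means among the compounds named here.

Two members of the series carry numbers in a functional assay on the whole organism for inhibition, with Mus musculus as the target, in the writhing test, with a stated time of 1 h, at a dose of 10 mg/kg by the oral route; on this read-out higher numbers stand for more inhibition at the one dose given (going by the name of the read-out) and lower numbers for less inhibition. Compound 1 `Cc1ccc(N2CCN(CCC(OC(N)=O)c3ccccc3)CC2)c(C)c1` gives 34% in this assay, and compound 2 `NC(=O)OC(CCN1CCN(c2ccccc2O)CC1)c1ccccc1` gives 37%. For the measured compounds named here, the only step between them, a number 3 percentage points higher from compound 1 to compound 2 (within the scatter), lies within the scatter, so the two numbers cannot be told apart and compound 2 is not set apart from compound 1 on these figures.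

Compound 3 `Cc1cccc(C)c1N1CCN(CCC(OC(N)=O)c2ccccc2)CC1` is the next member to be measured in this assay. It differs from compound 2 by 2,6-dimethylphenyl in place of 2-hydroxyphenyl on an amine nitrogen in a ring. Going by the values given here, the one measured step that touches this place is a number 3 percentage points higher from compound 1 to compound 2 (within the scatter), in which exchanging one group on that ring nitrogen for another moved the number by less than the scatter. The 2,6-dimethylphenyl that enters in compound 3 resembles the 2,4-dimethylphenyl carried by compound 1, and since that earlier exchange produced no step beyond the scatter, none beyond the scatter is expected here. The expected step from compound 2 to compound 3 is a number 2 percentage points lower from compound 2 to compound 3 (within the scatter). Compound 3 is therefore estimated to give 35% in this assay, with a range from 20% to 50%.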

Compound 3, a percentage reported as inhibition, in the whole organism at one dose (the size of the read-out at that dose, not a potency): 48%
Compound 3: middle estimate off by 13 percentage points, on the low side, and the stated range covers the measured number.
By their numbers in this assay, from the lowest: compounds 1 and 2 (each within the scatter of the next); then compound 3.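

In this assay, the group on the amine nitrogen in the ring now proves able to move the number: a number 11 percentage points higher from compound 2 to compound 3 (beyond the scatter), whereas the earlier exchange at this place, a number 3 percentage points higher from compound 1 to compound 2 (within the scatter), stayed within the scatter. The second new step, a number 14 percentage points higher from compound 1 to compound 3 (beyond the scatter), joins two dimethylphenyl groups with the same name apart from its numbers, so a dimethylphenyl group as such does not go with the higher number, and compound 1 stands against any such reading. The compounds shown offer no measurement that bears on why 2,6-dimethylphenyl gives this rise.

Still open is how far the number depends on an aryl group at this ring nitrogen at all, since the series shown holds no unsubstituted phenyl, benzyl or cyclohexyl group there, and whether any of these would match or pass compound 3. With a single dose per compound, the numbers give only the size of the effect at that dose and leave open how the three compounds would rank in potency.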